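The source may report more compounds than this note shows. Statements on the series, on what has been measured and on what is new or still open speak of the compounds shown alone.

In a functional assay on MCF7 cells (Homo sapiens) for inhibition (on this read-out higher numbers stand for weaker inhibition and lower numbers for stronger inhibition), compound 1 `O=C(CC(CC(=O)NC1Cc2ccccc2C1)c1ccc(Cl)cc1)NCCN1CCCCC1` gives 35500 nM and compound 2 `CCN(C(=O)CC(CC(=O)NCCN1CCCCC1)c1ccc(Cl)cc1)C1Cc2ccccc2C1` gives 16500 nM. Going by the values given here, compound 2 therefore holds the lowest of the two numeric values so far. The step between them is a 2.2-fold lower number from compound 1 to compound 2 (0.33 log units; beyond the scatter), and it comes with ethyl in place of hydrogen on an amide-type nitrogen.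

Compound 4 `CCN(CC)CCNC(=O)CC(CC(=O)N(CC)C1Cc2ccccc2C1)c1ccc(Cl)cc1` keeps that ethyl and changes the other end of the molecule: diethylamino in place of piperidin-1-yl on a saturated chain carbon, two bonds along the chain from an amide-type nitrogen. Among the compounds with values here, no measured step isolates diethylamino in place of piperidin-1-yl. Within the data shown here, the one measured step lies at a different place, so it bears on this change only as a guide to size, and that size is modest.

Compound 3 `CCN(CC)CCNC(=O)CC(CC(=O)N(C)C1Cc2ccccc2C1)c1ccccc1` also carries 2-(diethylamino)ethyl, and in this assay it reads > 100000 nM, which is a limit of the assay. It differs from compound 4 elsewhere too, so it supports no more than a slight lean towards a higher number.

A small change is therefore expected, with the direction only weakly indicated. The estimated step is a 1.5-fold higher number from compound 2 to compound 4 (0.18 log units; within the scatter). For compound 4 the expected value is 25000 nM, with an estimated range of 9000 nM to 70000 nM.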

Compound 4, half-maximal inhibitory concentration: 23000 nM
For compound 4 the middle estimate is 1.1-fold (0.04 log units) above the measured one; measured number inside the range.
By their numbers in this assay, from the lowest: compounds 2, 4 and 1 (each within the scatter of the next, the first and the last beyond it). At a limit, above all of these: compound 3.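

In this assay, diethylamino in place of piperidin-1-yl on a saturated chain carbon, two bonds along the chain from an amide-type nitrogen, gives a 1.4-fold higher number from compound 2 to compound 4 (0.14 log units; within the scatter), so at this position the six-membered non-aromatic ring can give way to a group with no ring without a change that stands out from the scatter. Compound 4 carries 2-(diethylamino)ethyl and reads 23000 nM in this assay. Compound 3 also carries 2-(diethylamino)ethyl and reads > 100000 nM, which is a limit and not a number: the limit of > 100000 nM in this assay, at which 1 of the 4 values shown sits.

On these data alone, the two amine ends seen so far give the same reading within the scatter, so it remains open whether a smaller dimethylamino, a morpholin-4-yl with its ring oxygen, or a carboxylic acid in place of the amine would move the number at this position. Also open, as far as these compounds go, is whether a propyl or longer chain leading to the amine would change the reading, and whether the step seen with ethyl on the amide nitrogen carries over to compounds with diethylamino.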